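A few compounds are considered here, and "the series" means these few. Any claim that something is new, unique, unknown or untested is made for them only; others in the source may bear on it.

Measured so far:
compound 1, `N=C(NCCCc1c[nH]cn1)NCCC(c1ccc(Cl)cc1)c1ccccn1`: 77.6 nM
compound 2, `N=C(NCCCc1c[nH]cn1)NCCC(c1ccc(F)cc1)c1cccnc1`: 195 nM

In a functional assay on ileum for antagonist activity at histamine H1 receptor (Cavia porcellus) (a lower number here means tighter binding, a higher number weaker binding), compound 1 gives 77.6 nM, and in this assay compound 2 gives 195 nM. Of the two numbers, compound 2 has the higher one; the gap to compound 1 is beyond the usual scatter, so compound 2 is the weaker of the pair. Compound 3, `N=C(NCCCc1c[nH]cn1)NCCC(Cc1ccccc1)c1ccc(F)cc1`, has not yet been tested. It differs from compound 2 in one place: benzyl in place of pyridin-3-yl on a saturated chain carbon bound to an aromatic carbon and a saturated chain carbon. Going by the values given here, no pair of measured compounds shows this change, so nothing already tested says directly how this assay will respond. Because compound 2 stands at 195 nM and the change is a modest one on the shared core, a moderate step is expected, more likely toward a higher number than a lower one, as a 1.8-fold higher number from compound 2 to compound 3 (0.25 log units; within the scatter). The estimate for compound 3 is 350 nM, with a range from 100 nM to 1200 nM.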

Compound 3, dissociation constant: 141 nM
For compound 3 the middle estimate is 2.5-fold (0.39 log units) above the measured one; the measured number falls inside the stated range.
By their numbers in this assay, from the lowest: compounds 1, 3 and 2 (each within the scatter of the next, the first and the last beyond it).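

In this assay, putting benzyl in place of pyridin-3-yl on a saturated chain carbon bound to an aromatic carbon and a saturated chain carbon gives a 1.4-fold lower number from compound 2 to compound 3 (0.14 log units; within the scatter). The group that leaves has a ring nitrogen and a hydrogen-bond acceptor while the group that enters is carbon only, yet this assay does not tell the two apart, so at this position neither that nitrogen nor that acceptor is needed to keep the number in this range. Nothing available here explains why the exchange leaves the number where it is.

Still open, from the compounds shown here alone, is how this position responds to something of a different kind, such as an amine or a carboxylic acid, in place of benzyl. Compound 1 differs from compound 2 and compound 3 in more than one place, so it cannot settle this question.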